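A Chloro-to-Methoxy Swap at the Assay Limit

This account rests on a few compounds, and the source may have more. Where it says the series, first, only, none or still open, it means among the compounds named here.

Of the compounds shown here, three sharing one core have been tested in a physicochemical assay for solubility, in phosphate buffer, measured as kinetic solubility, at pH 7.4; a higher number here means a more soluble compound, a lower number a less soluble compound: compound 1 `Cc1oc(-c2ccccc2Cl)nc1CN1CCC(C(=O)NCCCN2C[C@H](C)C[C@H](C)C2)CC1`, compound 2 `Cc1cccc(F)c1-c1nc(CN2CCC(C(=O)NCCCN3C[C@H](C)C[C@H](C)C3)CC2)c(C)o1` and compound 3 `COc1cccc(Cl)c1-c1nc(CN2CCC(C(=O)NCCCN3C[C@H](C)C[C@H](C)C3)CC2)c(C)o1`. Compound 1 gives > 72 ug/mL, which is a limit and not a number. Compound 2 gives > 72 ug/mL, again a limit. Going by these compounds, compound 3 gives > 76 ug/mL, also a limit, so its exact standing is unknown.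

Compound 4 `COc1cccc(OC)c1-c1nc(CN2CCC(C(=O)NCCCN3C[C@H](C)C[C@H](C)C3)CC2)c(C)o1` differs from compound 3 by one change: methoxy in place of chloro on an aromatic carbon. This is methoxy in place of chloro on an aromatic carbon, turning 2-chloro-6-methoxyphenyl into 2,6-dimethoxyphenyl.

Among the compounds with values here, three measured steps bear on this change: a step that the two limits leave unreadable from compound 1 to compound 2, a step that the two limits leave unreadable from compound 1 to compound 3 and a step that the two limits leave unreadable from compound 2 to compound 3. None has a readable size, but each alters groups on an aromatic carbon and all end at a limit. Since compound 3 stands at > 76 ug/mL, no step beyond the scatter is expected in this assay, in either direction. The estimated move is an at least 1.0-fold lower number from compound 3 to compound 4 (0.00 log units; that floor lies within the scatter). For compound 4 the expected value is 75 ug/mL, with an estimated range from 55 ug/mL to 95 ug/mL.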

Compound 4, solubility: > 76 ug/mL
Compound 4 ended at the assay's limit; the forecaster's own chance of this, stated with the estimate: 85%; middle value at least 1.0-fold (0.00 log units) from the limit.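

In this assay compound 4 gives > 76 ug/mL, which is a limit and not a number. Within the data shown here, compound 1, compound 2 and compound 3 also stand at limits, so no step to compound 4 can be read. Going by these compounds, whether these four compounds differ at all, and by how much, stays open.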